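Moving one methyl group on compound 3

The source may report more compounds than this note shows. Statements on the series, on what has been measured and on what is new or still open speak of the compounds shown alone.

Going by the values given here, in a functional assay on HepG2 cells (Homo sapiens) for antiproliferative activity, read by MTT assay, with a stated time of 48 h (on this read-out lower numbers stand for stronger inhibition and higher numbers for weaker inhibition), compound 3 (`Cc1ccccc1NC(=O)Nc1cccc(CNc2nccnc2Cl)c1`) gives 15300 nM as the higher of the two true numbers so far. Compound 2 (`O=C(Nc1cccc(CNc2nccnc2Cl)c1)Nc1ccc(Cl)cc1Cl`) gives 7230 nM as the other. Compound 1 (`CN(C)c1ccc(NC(=O)Nc2cccc(CNc3nccnc3Cl)c2)cc1`) reads > 40000 nM and this is a limit of this assay rather than a number.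

Compound 4 (`Cc1ccc(NC(=O)Nc2cccc(CNc3nccnc3Cl)c2)cc1`) carries 4-methylphenyl in place of 2-methylphenyl on an amide-type nitrogen with the same atoms joined differently. Among the compounds with values here, no measured step moves a methyl group. The closest evidence is whole-group swaps on that nitrogen, namely an at least 2.6-fold lower number from compound 1 to compound 3 (0.41 log units; beyond the scatter) and a 2.1-fold higher number from compound 2 to compound 3 (0.33 log units; beyond the scatter) in size. A small step of no firm direction is therefore expected, probably none beyond the scatter. The estimated change is a 1.1-fold higher number from compound 3 to compound 4 (0.05 log units; within the scatter) for now. For compound 4 the estimated value is 17000 nM with an expected range of 7000 nM to 40000 nM in this assay once measured.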

Compound 4, half-maximal inhibitory concentration: 11500 nM
Compound 4: the middle estimate sits 1.5-fold (0.17 log units) above what was measured, within the range that was stated.
By their numbers in this assay, from the lowest: compounds 2, 4 and 3 (each within the scatter of the next, the first and the last beyond it). At a limit, above all of these: compound 1.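

Moving the methyl group, with 4-methylphenyl in place of 2-methylphenyl, gives a 1.3-fold lower number from compound 3 to compound 4 (0.12 log units; within the scatter), so in this assay the two placements on this ring cannot be told apart. Against 2,4-dichlorophenyl, 4-methylphenyl gives a 1.6-fold higher number from compound 2 to compound 4 (0.20 log units; within the scatter), a closeness that 2-methylphenyl did not show. From the compounds shown here alone, with methyl in place of dimethylamino, the step of an at least 3.4-fold lower number from compound 1 to compound 4 (0.54 log units; beyond the scatter) clears the scatter, yet its true size stays open, since one end of it sits at a limit: the limit of > 40000 nM in this assay, at which 1 of the 4 values shown sits.

Going by these compounds, whether a primary amine or a carboxylic acid on this ring, or a longer chain such as propyl in place of methyl, would read differently remains open.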